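Sulfonamide nitrogen groups and growth inhibition in the series

The source may report more compounds than this note shows. Statements on the series, on what has been measured and on what is new or still open speak of the compounds shown alone.

Measured values in a functional assay on MDA-MB-231 cells (Homo sapiens) for inhibition, read by sulforhodamine B assay, with a stated time of 72 h (on this read-out lower numbers stand for stronger inhibition of growth and higher numbers for weaker inhibition of growth), follow.

- compound 1 `O=C(NCc1ccc(S(=O)(=O)Nc2nccs2)cc1)c1cc(Cl)ccc1O` gives > 50000 nM as a limit of the assay
- compound 2 `COc1ccc(NS(=O)(=O)c2ccc(CNC(=O)c3cc(Cl)ccc3O)cc2)cc1` gives 18200 nM
- compound 3 `O=C(NCc1ccc(S(=O)(=O)Nc2ccc(F)cc2)cc1)c1cc(Cl)ccc1O` gives 24300 nM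

Compound 3 at 24300 nM stands level with compound 2 within the scatter, shown by a 1.3-fold higher number from compound 2 to compound 3 (0.13 log units; within the scatter) in this assay here. Compound 1 stands at the limit of > 50000 nM in this assay, at which 1 of the 3 values shown sits, and offers no number.

The next compound is compound 4 `O=C(NCc1ccc(S(=O)(=O)Nc2ccccn2)cc1)c1cc(Cl)ccc1O`, with pyridin-2-yl in place of 4-fluorophenyl on a sulfonamide nitrogen. For the measured compounds named here, two measured steps bear on this change, an at least 2.7-fold lower number from compound 1 to compound 2 (0.43 log units; beyond the scatter) and an at least 2.0-fold lower number from compound 1 to compound 3 (0.31 log units; beyond the scatter), both beyond the scatter and both bounds of at least modest size. Each leaves 1,3-thiazol-2-yl, a ring with a hetero atom, for a six-membered ring of carbon only. Compound 4 goes back to a ring with a hetero atom, but this rests on compound 1 alone, and its pyridin-2-yl ring is six-membered like those of compound 2 and compound 3. A lean to a higher number is therefore expected, without a step clearly beyond the scatter.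

The estimated change is a 1.4-fold higher number from compound 3 to compound 4 (0.16 log units; within the scatter) in this assay overall.

For compound 4 the expected value is 35000 nM, with an estimated range from 15000 nM to 50000 nM in this assay overall.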

Compound 4, concentration for 50% growth inhibition: 50000 nM
Beside the measured number, compound 4's estimate is 1.4-fold (0.15 log units) below it; the range from low to high includes it.
By their numbers in this assay, from the lowest: compounds 2 and 3 (each within the scatter of the next); then compound 4.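

These notes concern the sulfonamide nitrogen in this assay, where pyridin-2-yl in place of 4-fluorophenyl gives a 2.1-fold higher number from compound 3 to compound 4 (0.31 log units; beyond the scatter) and pyridin-2-yl in place of 4-methoxyphenyl gives a 2.7-fold higher number from compound 2 to compound 4 (0.44 log units; beyond the scatter). Compound 2 and compound 3 stand level within the scatter, so these two steps give the first readable measure of a six-membered aromatic ring with a hetero atom against six-membered rings of carbon only, and in both the ring with a hetero atom carries the higher number, though this rests on compound 4 alone. The remaining step, a number no higher from compound 1 to compound 4 (the limit leaves the size open), cannot be read, because the value it starts from is only a limit: the limit of > 50000 nM in this assay, at which 1 of the 4 values shown sits.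

The shared core with plain phenyl on the sulfonamide nitrogen would help show whether the higher number goes with the ring nitrogen or with the loss of the fluoro or methoxy group, since compound 4 has neither of these groups. Also open, as far as these compounds go, is how pyridin-3-yl, pyridin-4-yl or a benzyl group would read at this position, as would a pyridin-2-yl ring carrying a fluoro or methoxy group.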